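This account rests on a few compounds, and the source may have more. Where it says the series, first, only, none or still open, it means among the compounds named here.

Measured compounds:
- compound 1, `CCCOC(=O)C1=C(C)NC(C)=C(C(=O)OCCC)C1c1csc(-c2ccc(Cl)cc2)n1`: 4800 nM
- compound 2, `CC1=C(C(=O)OCC(C)C)C(c2csc(-c3ccc(Cl)cc3)n2)C(C(=O)OCC(C)C)=C(C)N1`: 24900 nM
- compound 3, `CC1=C(C(=O)OC(C)(C)C)C(c2csc(-c3ccc(Cl)cc3)n2)C(C(=O)OC(C)(C)C)=C(C)N1`: 21000 nM

All three share the same core and differ only in the two ester groups flanking the ring. In an assay on isolated protein for antagonist activity at Voltage-dependent L-type calcium channel subunit alpha-1C (Cavia porcellus), with a stated time of 15 min (on this read-out higher numbers stand for weaker inhibition and lower numbers for stronger inhibition), compound 2 gives the highest of the three numbers. Compound 3 sits close to it, within the scatter of repeated measurements, so the two cannot be ranked against each other. Compound 1 lies further away, with a number beyond the scatter below that of compound 2, so compound 1 is the stronger inhibitor of that pair.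

Compound 4, `COC(=O)C1=C(C)NC(C)=C(C(=O)OCC(C)C)C1c1csc(-c2ccc(Cl)cc2)n1`, has not yet been measured in this assay. It comes from compound 2 by a single change: hydrogen in place of isopropyl on a saturated chain carbon bound to an oxygen next to a carbonyl group, so that one of the two isobutyl esters becomes a methyl ester while the other is kept.

Among the measured compounds shown here, no measured pair shows this exact change. Going by the fact that compound 1, with its smaller esters, gives a lower number than compound 2 in this assay, the expectation is that compound 4 moves in the same direction, by a step of a 3.6-fold lower number from compound 2 to compound 4 (0.55 log units; beyond the scatter). Compound 4 is therefore estimated at 7000 nM, with a range from 1800 nM to 27000 nM.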

Compound 4, half-maximal inhibitory concentration: 46900 nM
Compound 4: the middle estimate sits 6.7-fold (0.83 log units) below what was measured, outside the stated range (above it).
By their numbers in this assay, from the lowest: compound 1; then compounds 3, 2 and 4 (each within the scatter of the next, the first and the last beyond it).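

In this assay, swapping one isobutyl ester of compound 2 for a methyl ester while keeping the other gives a 1.9-fold higher number from compound 2 to compound 4 (0.27 log units; within the scatter), so the two compounds cannot be ranked against each other. Among the compounds shown here, this is the first pair here that differs in one place only, and it shows that, at this position, the isobutoxycarbonyl group can give way to methoxycarbonyl with no difference that this measurement can tell apart from repeat scatter. No measurement at hand offers an explanation for this result.

The compounds shown leave open what a methyl ester on both sides of the shared core would give, and whether the same swap would read the same way with a propyl ester as the partner. They also leave open what a carboxylic acid, an amide or a longer chain would give in place of this ester.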